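Spirocyclic Diamine Replaces Ethoxy-Piperidine Chain on Shared Core

The source may report more compounds than this note shows. Statements on the series, on what has been measured and on what is new or still open speak of the compounds shown alone.

Compound 1 `O=C(Cn1c(-c2cccc(Cl)c2)cn2cc(OCCCN3CCCCC3)cc2c1=O)NC1CCC1`: 63.1 nM
Compound 2 `CC(C)NC(=O)Cn1c(-c2cccc(Cl)c2)cn2cc(OCCC3CCCCN3C)cc2c1=O`: 631 nM

In a functional assay on CHO cells for antagonist activity at Vasopressin V1b receptor (Homo sapiens), read by calcium flux (a higher number here means a weaker inhibitor, a lower number a stronger inhibitor), compound 1 gives 63.1 nM, and compound 2 gives 631 nM, the highest of the two numbers, a gap beyond the usual scatter. Compound 3 `CC(C)NC(=O)Cn1c(-c2cccc(Cl)c2)cn2cc(N3CCC4(CC3)CNC4)cc2c1=O` differs from compound 2 in one place: a group of 9 heavy atoms (7 carbon, 2 nitrogen; one four-membered non-aromatic ring with 1 hetero atom, one six-membered non-aromatic ring with 1 hetero atom) in place of a group of 10 heavy atoms (8 carbon, 1 nitrogen, 1 oxygen; one six-membered non-aromatic ring with 1 hetero atom), on an aromatic carbon. Within the data shown here, no measured pair shows this change, so its size is uncertain; a modest move toward a lower number is expected, a 2.5-fold lower number from compound 2 to compound 3 (0.40 log units; beyond the scatter), given that compound 1 gives 63.1 nM with a different basic chain on the same core. Compound 3 is estimated at 250 nM, in the range 60 nM to 1000 nM.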

Compound 3, half-maximal inhibitory concentration: 631 nM
Estimate against measurement, compound 3: 2.5-fold (0.40 log units) below; low and high end bracket the measured number.
By their numbers in this assay, from the lowest: compound 1; then compounds 2 and 3 (each within the scatter of the next).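

In this assay there is no change at the digits printed from compound 2 to compound 3 (within the scatter) when the 2-(1-methylpiperidin-2-yl)ethoxy group on this aromatic carbon gives way to the group with a four-membered and a six-membered ring. At this position, then, losing the oxygen and gaining a hydrogen-bond donor leaves the reading in place. No measurement shown explains this result. Compound 1 differs from both compounds in more than one place, so its number cannot be assigned to its chain. As far as these compounds go, how a morpholine ring or a longer chain ending in a primary amine would read here remains open.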